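A few compounds are considered here, and "the series" means these few. Any claim that something is new, unique, unknown or untested is made for them only; others in the source may bear on it.

In a functional assay on T98G cells (Homo sapiens) for inhibition, read by MTT assay, with a stated time of 72 h (on this read-out lower numbers stand for stronger inhibition and higher numbers for weaker inhibition), compound 3 `CC1(C)CC(NC(=O)Nc2ccccc2Cl)c2cc(Cl)ccc2O1` reads 20000 nM and lies within the scatter of the other two measured compounds: compound 1 `CC1(C)CC(NC(=O)Nc2ccccc2Cl)c2cc(F)ccc2O1` reads 27000 nM and compound 2 `CC1(C)CC(NC(=O)NCc2ccccc2)c2cc(Br)ccc2O1` reads 38000 nM in this series. Compound 4 `CC1(C)CC(NC(=O)Nc2ccccc2Cl)c2cc(Br)ccc2O1` follows from compound 3 by bromo in place of chloro on an aromatic carbon with bromo in place of chloro on an aromatic carbon. The closest measured change is a 1.4-fold lower number from compound 1 to compound 3 (0.13 log units; within the scatter) with chloro in place of fluoro, a step within the scatter. Among the compounds with values here, compound 2 carries bromo but differs elsewhere too, so it supplies no direct step. No change beyond the scatter is expected in this assay and the estimated step is only a 1.1-fold lower number from compound 3 to compound 4 (0.05 log units; within the scatter) in a slightly lower direction. The estimate for compound 4 is 18000 nM with an expected range of 10000 nM to 33000 nM on repeat measurement.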

Compound 4, half-maximal inhibitory concentration: 11000 nM
For compound 4 the middle estimate is 1.6-fold (0.21 log units) above the measured one; the range from low to high includes it.
By their numbers in this assay, from the lowest: compounds 4, 3, 1 and 2 (each within the scatter of the next, the first and the last beyond it).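

On this aromatic carbon, in this assay, only the widest swap of halogens reaches beyond the scatter: bromo in place of fluoro gives a 2.5-fold lower number from compound 1 to compound 4 (0.39 log units; beyond the scatter), whereas bromo in place of chloro gives a 1.8-fold lower number from compound 3 to compound 4 (0.26 log units; within the scatter). With bromo held constant, 2-chlorophenyl in place of benzyl on the amide-type nitrogen gives a 3.5-fold lower number from compound 2 to compound 4 (0.54 log units; beyond the scatter), so the nitrogen substituent also moves the number beyond the scatter.

No evidence at hand accounts for these steps. Open, from the compounds shown here alone, is how an amine or a carboxylic acid on this aromatic carbon, or a longer chain on the amide-type nitrogen, would read.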